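The source may hold more compounds than are shown below. What is called first, only, known or untested is meant among the compounds shown, and "the series" means these compounds.

In a functional assay on DU-145 cells (Homo sapiens) for inhibition, read by trypan blue exclusion, with a stated time of 96 h (a lower number here means a stronger inhibitor of growth, a higher number a weaker inhibitor of growth), compound 2 `Cc1ccc(S/C(=C/c2ccc[nH]2)C(=O)c2ccc(Cl)cc2)cc1` gives 10000 nM, the lowest of the two numbers at hand. Compound 1 `CSc1ccc(/C=C(/SCc2ccc(Cl)cc2)C(=O)c2ccc(Cl)cc2)cc1`, which gives 25000 nM in this assay, stands a step higher, and that gap lies beyond the usual scatter. Compound 3 `O=C(/C(=C\c1ccc[nH]1)SCc1ccc(Cl)cc1)c1ccc(Cl)cc1` has not yet been measured in this assay. It differs from compound 2 in one place: 4-chlorobenzyl in place of 4-methylphenyl on a sulfur. Among the compounds with values here, no pair of measured compounds differs by this change alone, so there is no measured step to gauge it; compound 1 also carries a 4-chlorobenzyl on a sulfur, but it differs from compound 2 in a second place as well, and only its two values can be read. A modest shift toward a higher number is expected, as a 1.5-fold higher number from compound 2 to compound 3 (0.18 log units; within the scatter), though one that may well stay within the scatter. Compound 3 is therefore estimated at 15000 nM, within a range of 5000 nM to 40000 nM.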

Compound 3, concentration for 50% growth inhibition: 10000 nM
For compound 3 the middle estimate is 1.5-fold (0.18 log units) above the measured one; the range from low to high includes it.
By their numbers in this assay, from the lowest: compounds 2 and 3 (each within the scatter of the next); then compound 1.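

In this assay the change on the sulfur gives no change at the digits printed from compound 2 to compound 3 (within the scatter), so in this pair 4-chlorobenzyl and 4-methylphenyl cannot be told apart. Within the data shown here, on the double-bonded chain carbon, with 4-chlorobenzyl kept on the sulfur, 1H-pyrrol-2-yl in place of 4-(methylsulfanyl)phenyl gives a 2.5-fold lower number from compound 1 to compound 3 (0.40 log units; beyond the scatter), the only one of the two steps that lies beyond the scatter. No measurement at hand accounts for either step.

The compounds shown leave open whether a chain ending in an amine or a carboxylic acid on the sulfur would move the number in this assay. They also leave open how an unsubstituted phenyl or a furan-2-yl would compare with 1H-pyrrol-2-yl on the double-bonded chain carbon.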